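Carbamoyl in place of fluoro: from compound 1 to compound 4

The compounds below may be only part of what the source reports. "The series", "measured", "known", "first", "only" and "open" are said of these compounds alone.

For the measured compounds named here, compound 1 `CC[C@@H]1C(=O)N(C)c2cnc(-n3ccc4cc(F)ccc43)nc2N1C1CCCC1` gives the highest number of the three measured so far in a functional assay on NCI-H1975 cells (Homo sapiens) for antiproliferative activity, read by CCK-8 assay, with a stated time of 72 h (a lower number here means a stronger inhibitor of growth, a higher number a weaker inhibitor of growth), at 46500 nM. Compound 3 `CCC1C(=O)N(C)c2cnc(-n3ccc4cc(C(=O)NCC(C)C)ccc43)nc2N1c1ccn(C)n1` stands nearest with 10200 nM, and compound 2 `CC[C@@H]1C(=O)N(C)c2cnc(Nc3ccc(S(N)(=O)=O)cc3)nc2N1C1CCCC1` furthest with 5290 nM; both gaps to compound 1 are beyond the scatter. Compound 4 `CC[C@@H]1C(=O)N(C)c2cnc(-n3ccc4cc(C(N)=O)ccc43)nc2N1C1CCCC1` differs from compound 1 in one place: carbamoyl in place of fluoro on an aromatic carbon. The fluoro leaves and a carbamoyl enters, bringing one hydrogen-bond donor and one hydrogen-bond acceptor. Going by the values given here, no measured pair shows this exact change, so the step size must be judged from the whole set; compound 3 also carries an amide on its core and gives 10200 nM. A moderate improvement is expected, a step of a 3.9-fold lower number from compound 1 to compound 4 (0.59 log units; beyond the scatter). Compound 4 is estimated at 12000 nM, within 4000 nM to 40000 nM.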

Compound 4, concentration for 50% growth inhibition: 3380 nM
Compound 4: the middle estimate sits 3.6-fold (0.55 log units) above what was measured, and the stated range ends above it.
By their numbers in this assay, from the lowest: compounds 4, 2 and 3 (each within the scatter of the next, the first and the last beyond it); then compound 1.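

On the aromatic carbon para to a fused ring, a single change to the shared core moves the number substantially in this assay: carbamoyl in place of fluoro gives a 14-fold lower number from compound 1 to compound 4 (1.14 log units; beyond the scatter). For the compounds shown here, this is the first pair that differs in one place, so the size of a change at this position can now be read directly. Nothing measured accounts for the step. Still open, as far as these compounds go, is whether the step is specific to carbamoyl or would also appear with a nitrile, a carboxylic acid or a methylamide at this carbon.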